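Swapping chloro for fluoro on the aryl ring of compound 2

This account rests on a few compounds, and the source may have more. Where it says the series, first, only, none or still open, it means among the compounds named here.

Measured compounds:
- compound 1, `COc1nc(-c2nc3ccccc3n2C)cc(-c2ccc(Cl)cc2)c1C#N`: 145000 nM
- compound 2, `CCOc1nc(-c2nc3ccccc3n2C)cc(-c2ccc(Cl)cc2)c1C#N`: 293000 nM
- compound 3, `COc1nc(-c2nc3ccccc3n2C)cc(-c2ccc(Cl)cc2Cl)c1C#N`: 214000 nM

All three compounds were tested in a functional assay on aorta (Rattus norvegicus, strain Wister); on this read-out higher numbers stand for weaker inhibition and lower numbers for stronger inhibition. Compound 2 gives the highest of the three numbers, though its distance to compound 3 is within the scatter; only its distance to compound 1 lies beyond it, as the step of a 2.0-fold higher number from compound 1 to compound 2 (0.31 log units; beyond the scatter) shows.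

Compound 4, `CCOc1nc(-c2nc3ccccc3n2C)cc(-c2ccc(F)cc2)c1C#N`, differs from compound 2 by fluoro in place of chloro on an aromatic carbon. Among the measured compounds shown here, no measured step exchanges one halogen for another. The nearest comparison is a 1.5-fold higher number from compound 1 to compound 3 (0.17 log units; within the scatter), which touches the same kind of aryl ring and stays within the scatter. On that basis only a small step is expected in this assay, in no particular direction and probably not beyond the scatter. Compound 4 is therefore expected to give about 300000 nM, with a range from 120000 nM to 750000 nM, which would mean a step of a 1.0-fold higher number from compound 2 to compound 4 (0.01 log units; within the scatter).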

Compound 4, half-maximal inhibitory concentration: 362000 nM
The estimate for compound 4 lay 1.2-fold (0.08 log units) below the measured number; the measured number falls inside the stated range.
By their numbers in this assay, from the lowest: compounds 1, 3, 2 and 4 (each within the scatter of the next, the first and the last beyond it).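

In this assay, among the compounds shown here, the change from 4-chlorophenyl to 4-fluorophenyl gives a 1.2-fold higher number from compound 2 to compound 4 (0.09 log units; within the scatter) and so supplies the first exchange of one halogen for another. For the compounds shown here, at this aromatic carbon, para to a large group, the chloro and fluoro compounds cannot be told apart, just as the added chloro of compound 3 gives only a 1.5-fold higher number from compound 1 to compound 3 (0.17 log units; within the scatter) on the same aryl ring, while the one step beyond the scatter remains a 2.0-fold higher number from compound 1 to compound 2 (0.31 log units; beyond the scatter) on the chain bound to the oxygen. Nothing available accounts for this result.

Going by these compounds, whether a group other than a halogen at this place, such as an amine or a carboxylic acid, would move the number beyond the scatter stays open. So does the effect of a longer chain on the oxygen of compound 4.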